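Swapping one halogenated phenyl for another in two settings

The source may hold more compounds than are shown below. What is called first, only, known or untested is meant among the compounds shown, and "the series" means these compounds.

Two measured compounds share a core and differ only in a phenyl group on an amide-type nitrogen. Compound 1 `O=C(CSc1nc(Nc2ccccc2)c2ccccc2n1)Nc1ccc(Cl)cc1Cl` and compound 2 `O=C(CSc1nc(Nc2ccccc2)c2ccccc2n1)Nc1ccc(F)c(Cl)c1` were both tested in a functional assay on NCI-H1975 cells (Homo sapiens) for inhibition, read by MTT assay, with a stated time of 72 h; on this read-out lower numbers stand for stronger inhibition and higher numbers for weaker inhibition. In this assay compound 1 gives 8410 nM, and compound 2 gives 9390 nM. The change between them is 2,4-dichlorophenyl in place of 3-chloro-4-fluorophenyl on an amide-type nitrogen, and the step it made is a 1.1-fold lower number from compound 2 to compound 1 (0.05 log units; within the scatter), so the two values cannot be told apart.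

Compound 3 `C=CC(=O)Nc1cccc(NC(=O)CSc2nc(Nc3ccc(F)c(Cl)c3)c3ccccc3n2)c1` carries a different core; how the core of compound 3 differs from that of compound 2 is not broken down here. In this assay compound 3 reaches only the limit of the measurement, > 50000 nM, which is a limit and not a number, as seen in the limit of > 50000 nM in this assay, at which 1 of the 3 values shown sits.

Compound 4 `C=CC(=O)Nc1cccc(NC(=O)CSc2nc(Nc3ccc(Cl)cc3Cl)c3ccccc3n2)c1` has not been measured. It differs from compound 3 by 2,4-dichlorophenyl in place of 3-chloro-4-fluorophenyl on a nitrogen on an aromatic ring. This is the same kind of change as that from compound 2 to compound 1, but not the same: there it sat on an amide-type nitrogen whose other neighbour is a carbonyl carbon, here it sits on a nitrogen on an aromatic ring whose other neighbour is an aromatic carbon. Because the earlier step was a 1.1-fold lower number from compound 2 to compound 1 (0.05 log units; within the scatter), the step from compound 3 to compound 4 is expected to be small as well, estimated at a step that the limit leaves unreadable from compound 3 to compound 4. Compound 4 is therefore expected to give about 60000 nM in this assay, likely again only a limit, with a range from 20000 nM to 200000 nM.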

Compound 4, half-maximal inhibitory concentration: 5990 nM
The estimate for compound 4 lay 10-fold (1.00 log units) above the measured number; measured number outside the range, below it.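

Placing 2,4-dichlorophenyl in this assay where 3-chloro-4-fluorophenyl stood, on a nitrogen on an aromatic ring, gives an at least 8.3-fold lower number from compound 3 to compound 4 (0.92 log units; beyond the scatter), so here the swap goes with a clear drop in the number. With only one pair on each core, this shows that the size of the step did not carry over from one setting to the other, not that it never does, and the swap did not sit on the same kind of nitrogen in the two pairs: the same change on two cores in this assay, a 1.1-fold lower number (0.05 log units; within the scatter) from compound 2 to compound 1 and an at least 8.3-fold lower number (0.92 log units; beyond the scatter) from compound 3 to compound 4, at least 7.4-fold (0.87 log units) apart, beyond the scatter of two such steps Compound 3 gives > 50000 nM, which is a limit of the assay and not a number, so the step has a known minimum but no known full size, and nothing shown explains why the two settings differ: the limit of > 50000 nM in this assay, at which 1 of the 4 values shown sits.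

The compounds shown leave open whether the larger step belongs to these two halogenated phenyl groups alone or would also appear with other groups on that nitrogen, such as a phenyl carrying an amine or a carboxylic acid. They also leave open which part of the core of compound 3 makes the swap count for so much more there.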